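Hydrazone series: cytotoxicity across the aryl substituent

The compounds below may be only part of what the source reports. "The series", "measured", "known", "first", "only" and "open" are said of these compounds alone.

Compound 1 `O=C(COc1cccc2ccccc12)N/N=C/c1ccc(Cl)cc1` and compound 2 `O=C(COc1cccc2ccccc12)N/N=C/c1ccc(Br)cc1` share one core and differ only in the halogen on the aryl ring. In an ADME assay on HEL cells (Homo sapiens) for cytotoxicity (on this read-out higher numbers stand for lower toxicity in this test and lower numbers for higher toxicity in this test), compound 1 gives 100 ug/mL. For compound 2 the read-out is a limit of the test, > 100 ug/mL, not a number. The step of a number no lower from compound 1 to compound 2 (the limit leaves the size open) therefore cannot be sized; it rests on (the limit of > 100 ug/mL in this assay, at which 1 of the 2 values shown sits). Compound 2 thus stands at the limit of the test, without a number of its own. Compound 3 `O=C(COc1cccc2ccccc12)N/N=C/c1ccc([N+](=O)[O-])cc1` carries the change (nitro in place of bromo on an aromatic carbon). Among the compounds with values here, only one measured step is at hand, and it is unsized, so no direction can be drawn from it for the nitro change. Compound 3 is therefore expected to give 100 ug/mL, within 50 ug/mL to 100 ug/mL, with a fair chance that only a limit is again reported. The expected step of a number no higher from compound 2 to compound 3 (the limit leaves the size open) is none beyond the scatter.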

Compound 3, minimum cytotoxic concentration: 20 ug/mL
Beside the measured number, compound 3's estimate is 5.0-fold (0.70 log units) above it, and the stated range ends above it.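

On this aromatic carbon, para to a large group, the read-out is not indifferent to the substituent: in this assay, nitro in place of bromo gives an at least 5.0-fold lower number from compound 2 to compound 3 (0.69 log units; beyond the scatter). Compound 2 enters that step only through a limit of the test, not a number: the limit of > 100 ug/mL in this assay, at which 1 of the 3 values shown sits. The comparison with chloro needs no limit and gives a 5.0-fold lower number from compound 1 to compound 3 (0.70 log units; beyond the scatter), so among the three compounds shown, nitro is the change that brings a sized step beyond the scatter, towards higher toxicity in this test.

With only one non-halogen group here, the compounds shown leave open whether this step is particular to nitro. Going by these compounds, how an amine or a carboxylic acid on the same aromatic carbon would read in this assay also remains open.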